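The compounds below may be only part of what the source reports. "The series", "measured", "known", "first", "only" and "open" are said of these compounds alone.

In a functional assay on BXPC-3 cells (Homo sapiens) for inhibition, read by MTT assay, with a stated time of 7 days (on this read-out lower numbers stand for stronger inhibition and higher numbers for weaker inhibition), compound 1 `CCCN(CCC)S(=O)(=O)c1ccc(S(=O)(=O)N2CCC[C@@H](C(=O)OCC)C2)cc1` gives 2500 nM, and compound 2 `CCOC(=O)[C@@H]1CCCN(S(=O)(=O)c2ccc(S(=O)(=O)N(C)C)cc2)C1` gives 1000 nM. Among the measured compounds shown here, the only change between them is dimethylamino in place of dipropylamino on a sulfonyl sulfur, and the step of a 2.5-fold lower number from compound 1 to compound 2 (0.40 log units; beyond the scatter) carries it. On the two numbers seen so far compound 2 stands lowest, with compound 1 nearest at a higher number beyond the scatter.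

Compound 3 `CCOC(=O)[C@@H]1CCCN(S(=O)(=O)c2ccc(S(=O)(=O)N(C)Cc3ccccc3)cc2)C1` differs from compound 2 by phenyl in place of hydrogen on a saturated chain carbon bound to a sulfonamide nitrogen; cut one bond further out, the same difference reads methyl to benzyl, or dimethylamino to benzyl(methyl)amino. For the measured compounds named here, the one measured step that touches this amine on the sulfonyl sulfur is a 2.5-fold lower number from compound 1 to compound 2 (0.40 log units; beyond the scatter), in which a change of the two alkyl groups moved the number a modest distance. Going by the values given here, no measured pair shows a phenyl ring entering at this place, so the direction of the new step is not fixed by the data. A modest step toward a higher number, or none beyond the scatter, is expected, with the step of a 2.0-fold higher number from compound 2 to compound 3 (0.30 log units; within the scatter) as the estimate. For compound 3 the expected value in this assay is 2000 nM, within a range from 700 nM to 6000 nM.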

Compound 3, half-maximal inhibitory concentration: > 30000 nM
Compound 3 gave a limit, no number (the forecaster's own chance of this, stated with the estimate: 5%); middle value at least 15-fold (1.17 log units) away from the limit.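

In this assay compound 3 gives a limit of the assay and not a number: the limit of > 30000 nM in this assay, at which 1 of the 3 values shown sits.

Phenyl in place of hydrogen on a saturated chain carbon bound to a sulfonamide nitrogen gives an at least 30-fold higher number from compound 2 to compound 3 (1.47 log units; beyond the scatter), a large step, whereas the only earlier change at this amine moved the number a modest distance. Benzyl(methyl)amino in place of dipropylamino gives an at least 12-fold higher number from compound 1 to compound 3 (1.07 log units; beyond the scatter), so among the three compounds shown, the two amines bearing only alkyl groups give numbers in this assay, while the amine bearing benzyl gives only a limit, and this position proves far less tolerant of change than the first step suggested.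

Going by these compounds, since compound 3 gives a limit, the full size of both steps stays unknown, and a single compound cannot tell whether the aromatic ring itself or simply the larger group goes with the loss. On these data alone, a cyclohexylmethyl group on the same nitrogen would bear on that question, and how a pyridylmethyl or a longer phenylethyl chain would read at this place also remains open.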